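Anilinoquinazoline series: halogen swap at the anilino ring

The source may report more compounds than this note shows. Statements on the series, on what has been measured and on what is new or still open speak of the compounds shown alone.

Measured compounds:
compound 1, `Clc1cccc(Nc2ncnc3ccc(NCc4ccc5c(c4)OCCO5)cc23)c1`, 28 ug/mL
compound 2, `O=C(Nc1ccc2ncnc(Nc3cccc(Br)c3)c2c1)C1COc2ccccc2O1`, 42.9 ug/mL

In a functional assay on A-431 cells (Homo sapiens) for antiproliferative activity, read by WST assay, with a stated time of 48 h (on this read-out higher numbers stand for weaker inhibition and lower numbers for stronger inhibition), compound 2 gives 42.9 ug/mL. Among the compounds with values here, compound 1, the only other measured member, gives 28 ug/mL in this assay; the two numbers sit within the usual scatter of one another, so no ranking between compound 1 and compound 2 can be read from them. Within the data shown here, no step between two measured compounds that differ in a single place is available.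

Compound 3, `O=C(Nc1ccc2ncnc(Nc3cccc(Cl)c3)c2c1)C1COc2ccccc2O1`, differs from compound 2 in one place: chloro in place of bromo on an aromatic carbon. Only the halogen on the anilino ring changes, and both compounds share the amide-linked core of compound 2. Among the measured compounds shown here, with no measured pair to calibrate this exchange, a step from compound 2 to compound 3 of no more than the scatter is expected in this assay, with no set direction, which is what a 1.1-fold lower number from compound 2 to compound 3 (0.03 log units; within the scatter) expresses. Compound 3 is therefore expected to give about 40 ug/mL in this assay, within 15 ug/mL to 110 ug/mL.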

Compound 3, half-maximal inhibitory concentration: 19.9 ug/mL
Estimate against measurement, compound 3: 2.0-fold (0.30 log units) above, and the stated range covers the measured number.
By their numbers in this assay, from the lowest: compounds 3, 1 and 2 (each within the scatter of the next, the first and the last beyond it).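

In this assay, the change from 3-bromophenyl to 3-chlorophenyl gives a 2.2-fold lower number from compound 2 to compound 3 (0.33 log units; beyond the scatter). Within the data shown here, this is the only single-place step, and it shows that the read-out responds to the identity of the halogen at this position, though only modestly. The exchange leaves the heavy-atom, hydrogen-bond donor and hydrogen-bond acceptor counts unchanged, and nothing available bears on why the number moves.

Open questions are how fluoro, methyl or ethynyl would read at this position, and whether an amine or a carboxylic acid on the same ring would be tolerated. Going by these compounds, it also remains open whether the same halogen exchange would give a step of similar size and direction on the core of compound 1.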